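Cinnamoyl hydroxamate series: trifluoromethyl replacing methyl on the sulfonyl aryl

The compounds below may be only part of what the source reports. "The series", "measured", "known", "first", "only" and "open" are said of these compounds alone.

Three members of the series have been run in a functional assay on MCF7 cells (Homo sapiens) for antiproliferative activity; on this read-out higher numbers stand for weaker inhibition of growth and lower numbers for stronger inhibition of growth. Compound 1 `Cc1ccc(S(=O)(=O)N2CCN(c3ncc(C(=O)NO)s3)CC2)cc1` gives 350 nM. Compound 2 `O=C(/C=C/c1cnc(N2CCN(S(=O)(=O)c3ccc(OC(F)(F)F)cc3)CC2)s1)NO` gives 6000 nM. Compound 3 `Cc1ccc(S(=O)(=O)N2CCN(c3ncc(/C=C/C(=O)NO)s3)CC2)cc1` gives 2000 nM. On these numbers compound 3 holds the second highest value of the three: the step of a 5.7-fold higher number from compound 1 to compound 3 (0.76 log units; beyond the scatter) separates it from compound 1, and the step of a 3.0-fold lower number from compound 2 to compound 3 (0.48 log units; beyond the scatter) from compound 2.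

Compound 4 `O=C(/C=C/c1cnc(N2CCN(S(=O)(=O)c3ccc(C(F)(F)F)cc3)CC2)s1)NO` is not yet measured. It differs from compound 3 by trifluoromethyl in place of methyl on an aromatic carbon. Among the measured compounds shown here, only one measured step touches the same position of the shared core: a 3.0-fold lower number from compound 2 to compound 3 (0.48 log units; beyond the scatter), in which a trifluoromethoxy group gave way to methyl and the number fell. The present change runs the other way, methyl giving way to a fluorinated group, though trifluoromethyl is not trifluoromethoxy, so the match is loose. Nothing else in the set bears on this position.

On that basis a modest rise in this assay is expected from compound 3 to compound 4, roughly a 2.0-fold higher number from compound 3 to compound 4 (0.30 log units; within the scatter), with a smaller movement within the scatter not excluded. Compound 4 is therefore estimated at 4000 nM in this assay, in the range 1500 nM to 11000 nM.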

Compound 4, concentration for 50% growth inhibition: 3000 nM
Compound 4: the middle estimate sits 1.3-fold (0.12 log units) above what was measured, within the range that was stated.
By their numbers in this assay, from the lowest: compound 1; then compounds 3, 4 and 2 (each within the scatter of the next, the first and the last beyond it).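

In this assay, trifluoromethyl in place of methyl on the aromatic carbon gives a 1.5-fold higher number from compound 3 to compound 4 (0.18 log units; within the scatter) and trifluoromethyl in place of trifluoromethoxy gives a 2.0-fold lower number from compound 2 to compound 4 (0.30 log units; within the scatter) so compound 4 cannot be separated from either compound 3 or compound 2 on this read-out. Among the compounds shown here, the only step previously available at this position, a 3.0-fold lower number from compound 2 to compound 3 (0.48 log units; beyond the scatter) remains beyond the scatter, but compound 4 now occupies the interval between its two ends and shows that a fluorinated group here need not produce a separation from methyl that exceeds the scatter; across these three compounds, only the trifluoromethoxy and methyl pair is resolved. No measurement is available that would explain the behaviour of this position.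

On these data alone, whether an amine, a carboxylic acid or a longer chain on the same aromatic carbon would move the number beyond the interval set by these three groups remains open. Also open, as far as these compounds go, is whether trifluoromethyl in place of methyl would read the same with hydroxycarbamoyl on the shared core, as in compound 1, where the step of a 5.7-fold higher number from compound 1 to compound 3 (0.76 log units; beyond the scatter) shows that this other position carries a change beyond the scatter.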